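This account rests on a few compounds, and the source may have more. Where it says the series, first, only, none or still open, it means among the compounds named here.

Working notes on the series, with all numbers from a functional assay on SK-BR-3 cells (Homo sapiens) for cytotoxicity, read by MTT assay, with a stated time of 72 h; a higher number here means a weaker inhibitor, a lower number a stronger inhibitor. Of the compounds shown here, two have been measured so far. Compound 1 (`CC(C)(C)OC(=O)N1CCN(c2c(C(=O)NCc3ccc(F)cc3)nc(Br)c3cccnc23)CC1`) gives 3000 nM and compound 2 (`C[C@H](NC(=O)c1nc(Br)c2cccnc2c1N[C@H]1CC[C@H](N)CC1)c1ccc(F)cc1`) gives 9000 nM. Compound 1 therefore holds the lower of the two numbers and is the stronger inhibitor of the pair, with a gap beyond the usual scatter.

Compound 3 (`O=C(NCc1ccc(F)cc1)c1nc(Br)c2cccnc2c1N1CCNCC1`) has not yet been measured in this assay. It keeps the core of compound 1 and differs in one place: hydrogen in place of tert-butoxycarbonyl on an amine nitrogen in a ring. Among the compounds with values here, no measured pair shows this change, so there is no direct precedent for its size. Within the data shown here, the only guide is the range so far, from compound 1 at 3000 nM to compound 2 at 9000 nM, so a large step is not expected. A modest move towards a lower number is expected, not beyond the scatter. The estimated step is a 1.5-fold lower number from compound 1 to compound 3 (0.18 log units; within the scatter). For compound 3 the expected value is 2000 nM, with an estimated range from 500 nM to 8000 nM.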

Compound 3, half-maximal inhibitory concentration: 6000 nM
The estimate for compound 3 lay 3.0-fold (0.48 log units) below the measured number, within the range that was stated.
By their numbers in this assay, from the lowest: compounds 1, 3 and 2 (each within the scatter of the next, the first and the last beyond it).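

In this assay, within the data shown here, the pair gives the only direct reading at this position: a 2.0-fold higher number from compound 1 to compound 3 (0.30 log units; within the scatter) for hydrogen in place of tert-butoxycarbonyl on an amine nitrogen in a ring. The two compounds therefore cannot be told apart in this assay, even though the change removes a group of 7 heavy atoms with 2 hydrogen-bond acceptors and leaves the rest of the core of compound 1 intact, so the series gives no sign that tert-butoxycarbonyl is required on this nitrogen for the activity seen. Nothing available explains the size of this step.

Going by these compounds, the pair tests only the two extremes of hydrogen and tert-butoxycarbonyl, so it remains open whether a small alkyl group such as methyl, an acetyl group, a longer chain or a chain ending in a carboxylic acid on this nitrogen would give a step beyond the scatter. Compound 2 differs from compound 3 in more than one place, so it also leaves open how the piperazine-type attachment and the amine-bearing substituent of compound 2 compare on their own.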